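This account rests on a few compounds, and the source may have more. Where it says the series, first, only, none or still open, it means among the compounds named here.

Measured in an ADME assay on CEMx174 cells (Homo sapiens) for cytotoxicity (on this read-out lower numbers stand for higher toxicity in this test and higher numbers for lower toxicity in this test), each value a limit and not a number:

Compound 1 `CC1=C(C(=O)OC2CCCCC2)C(c2cccc(O)c2)NC(=O)N1` gives > 10000 nM as a limit
Compound 2 `CC1=C(C(=O)OCC2CCCCC2)C(c2cccc(O)c2)N(C)C(=O)N1` gives > 10000 nM as a limit
Compound 3 `CCC1=C(C(=O)OCC2CCCCC2)C(c2ccc(N)cc2)NC(=O)N1` gives > 10000 nM as a limit

Compound 3 stands at > 10000 nM as a limit, with no exact number. The set as a whole shows the limit of > 10000 nM in this assay, at which 3 of the 3 values shown sit, and nothing finer. Going from compound 3 to compound 4 `CCC1=C(C(=O)OCC2CCCCC2)C(c2ccc(Cl)cc2)NC(=O)N1` puts chloro in place of amino on an aromatic carbon, para to a large group, as counted in chloro in place of amino on an aromatic carbon here. Going by the values given here, no measured pair differs in one place alone. In this assay no step beyond the usual scatter is expected, and another limit is likely. This expectation rests on compound 3 with > 10000 nM as its limit. The expected step is a number no higher from compound 3 to compound 4 (the limit leaves the size open) in size. For compound 4 the estimated value is 10000 nM with 4000 nM to 30000 nM as its expected range.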

Compound 4, half-maximal cytotoxic concentration: > 10000 nM
Compound 4 gave a limit, no number (the forecaster's own chance of this, stated with the estimate: 75%); the middle value sits exactly at the limit.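

Compound 3 and compound 4 each give only a limit in this assay, so no step between them can be read: the limit of > 10000 nM in this assay, at which 4 of the 4 values shown sit.

The compounds shown leave open at what concentration any of them harms these cells, and whether chloro in place of amino changes that.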